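The compounds below may be only part of what the source reports. "The series", "measured", "known", "first", "only" and "open" are said of these compounds alone.

Working notes on the series. Compound 1 `COc1cc(CNC(=O)CCCCCCC(C)C)ccc1OC(=O)c1ccc(C(N)=S)cc1` and compound 2 `COc1cc(CNC(=O)CCCC/C=C/C(C)C)ccc1OC(=O)c1ccc(C(N)=S)cc1` share one core; compound 3 `COc1cc(CNC(=O)CCCC/C=C/C(C)C)ccc1OCCCCOc1ccc(-c2cc(=S)ss2)cc1` and compound 4 `COc1cc(CNC(=O)CCCCCCC(C)C)ccc1OCCCCOc1ccc(-c2cc(=S)ss2)cc1` share another. The difference between the two cores is not broken down here.

In a functional assay on MCF7 cells (Homo sapiens) for antiproliferative activity, read by MTT assay, with a stated time of 48 h (on this read-out higher numbers stand for weaker inhibition and lower numbers for stronger inhibition), compound 2 gives 39400 nM. Compound 1 reaches only a limit of the assay, > 50000 nM, which is a limit and not a number. The change from compound 2 to compound 1 is isopentyl in place of 3-methylbut-1-en-1-yl on a saturated chain carbon, four bonds along the chain from a carbonyl carbon. The step that came with it, an at least 1.2-fold higher number from compound 2 to compound 1 (0.10 log units; that floor lies within the scatter), rests on (the limit of > 50000 nM in this assay, at which 1 of the 3 values shown sits), and its floor lies within the usual scatter, so the two values cannot be placed in order on this read-out.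

In this assay compound 3 gives 36400 nM. Compound 3 and compound 2 stand within the scatter of each other, so no order between them is claimed.

Compound 4 carries the same change on the second core: isopentyl in place of 3-methylbut-1-en-1-yl on a saturated chain carbon, four bonds along the chain from a carbonyl carbon. The place is the same in both pairs, so this is the same change, not merely the same kind. Among the measured compounds shown here, since the first instance gave no step beyond the scatter and one value at a limit, the expected step from compound 3 to compound 4 is a 1.2-fold higher number from compound 3 to compound 4 (0.09 log units; within the scatter), a small drift toward the weaker end that rests on an at least 1.2-fold higher number from compound 2 to compound 1 (0.10 log units; that floor lies within the scatter) and on the chance that a limit is reached again.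

In this assay compound 4 is expected near 45000 nM, estimated between 25000 nM and 80000 nM.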

Compound 4, half-maximal inhibitory concentration: 49500 nM
Compound 4: the middle estimate sits 1.1-fold (0.04 log units) below what was measured, within the range that was stated.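

Carrying the change from 3-methylbut-1-en-1-yl to isopentyl onto the second core gives, in this assay, a 1.4-fold higher number from compound 3 to compound 4 (0.13 log units; within the scatter), so on this core the change produces no step beyond the usual scatter and the two compounds cannot be placed in order. Set beside the first instance, this shows only that neither core gives a step that can be read as beyond the scatter, and it does not establish that the change carries over with the same size on both cores: the same change on two cores in this assay, an at least 1.2-fold higher number (0.10 log units; that floor lies within the scatter) from compound 2 to compound 1 and a 1.4-fold higher number (0.13 log units; within the scatter) from compound 3 to compound 4; the limit leaves it open whether they differ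

The first instance also cannot give a firm size, and it does not show that the change is without any effect in this series, as compound 1 stands at a limit and not at a number: the limit of > 50000 nM in this assay, at which 1 of the 4 values shown sits.

The compounds shown leave open whether a shorter or longer chain in place of isopentyl, or an amine or a carboxylic acid at the end of the chain, would give a step beyond the scatter on either core. They also leave open how the cis form of 3-methylbut-1-en-1-yl would read in this assay, and whether the same change would behave alike on a third core.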